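The source may report more compounds than this note shows. Statements on the series, on what has been measured and on what is new or still open speak of the compounds shown alone.

Measured compounds:
compound 1 `COc1ccc(-c2cc(/C=C/C(=O)c3ccc(N)cc3)[nH]n2)cc1` gives 72% in a functional assay on SF-539 cells (Homo sapiens) for cytotoxicity, read by sulforhodamine B assay, with a stated time of 48 h, tested at 1 uM; on this read-out lower numbers stand for a stronger effect and higher numbers for a weaker effect at the one concentration tested
compound 2 `COc1ccc(C(=O)/C=C/c2cc(-c3cc(OC)c(OC)c(OC)c3)n[nH]2)cc1` gives 87% in this assay
compound 3 `COc1cc(-c2cc(/C=C/C(=O)c3ccc(F)c(F)c3)[nH]n2)cc(OC)c1OC` gives 90% in this assay

Compound 1 stands lowest of the three numbers in this assay, meaning the strongest effect seen here; compound 2 lies beyond the scatter above it, and compound 3 lies further still. For the measured compounds named here, the one measured step changes the ring attached to the carbonyl carbon: a number 3 percentage points higher from compound 2 to compound 3 (within the scatter). That step touches a different part of the shared core than the change now in question and gives no guidance for it.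

Compound 4 `COc1ccc(-c2cc(/C=C/C(=O)c3ccc(N)cc3)[nH]n2)cc1OC` differs from compound 1 as follows: methoxy in place of hydrogen on an aromatic carbon. Going by the values given here, no measured pair isolates this change. Compounds 2 and 3 carry a ring with more methoxy groups on the same side of the core as compound 1's single methoxy, and both sit higher than compound 1, but they differ from compound 1 elsewhere too, so this is a hint and not a step. A small rise, or no step beyond the scatter, is therefore expected: a number 6 percentage points higher from compound 1 to compound 4 (within the scatter). Compound 4 is estimated at 78%, within 60% to 95%.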

Compound 4, a percentage reported as activity, at one concentration (the size of the read-out at that concentration, not a potency): 88%
Beside the measured number, compound 4's estimate is 10 percentage points below it, and the stated range covers the measured number.
By their numbers in this assay, from the lowest: compound 1; then compounds 2, 4 and 3 (each within the scatter of the next).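

For the compounds shown here, this is the first clean reading of this change: methoxy in place of hydrogen on an aromatic carbon, ortho to a methoxy group, gives a number 16 percentage points higher from compound 1 to compound 4 (beyond the scatter) in this assay. This position is therefore not indifferent: the added methoxy group goes with a weaker effect at the one concentration tested. Nothing measured here on the compounds explains the rise.

Still open, going by these compounds, is whether the rise belongs to methoxy itself or to any group other than hydrogen at this place, and a fluorine atom, a hydroxy group or an ethoxy group there would help separate those readings. Also open, on these data alone, is whether the same change would act alike with another ring on the carbonyl carbon, as this one pair speaks only for compound 1 and compound 4.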